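Phenoxy for Phenyl: Cytotoxicity on Vero Cells

The source may report more compounds than this note shows. Statements on the series, on what has been measured and on what is new or still open speak of the compounds shown alone.

Going by the values given here, compound 1 `CN1Cc2ccc(OCc3ccc(-c4ccccc4)cc3)cc2[C@@H](O)C1` is the only member of this small set with a number rather than a limit to its name. In an ADME assay on Vero cells (Chlorocebus sabaeus) for cytotoxicity, read by sulforhodamine B assay, with a stated time of 72 h (a higher number here means a weaker inhibitor, a lower number a stronger inhibitor), compound 1 gives 23000 nM. Compound 2 `CN1Cc2ccc(OCc3cccnc3)cc2[C@@H](O)C1` differs from compound 1 elsewhere in the molecule. In this assay compound 2 reaches only a limit, > 50000 nM. Among the compounds with values here, the sole other entry beside compound 1 is therefore (the limit of > 50000 nM in this assay, at which 1 of the 2 values shown sits), so compound 1 can only be said to fall on the measurable side of it.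

Compound 3 `CN1Cc2ccc(OCc3ccc(Oc4ccccc4)cc3)cc2[C@@H](O)C1` has not yet been measured. It differs from compound 1 by phenoxy in place of phenyl on an aromatic carbon. The measured pairs contain no comparable change, so there is no measured basis for the size of this step. A step in this assay of no more than the usual scatter is expected, in either direction. The estimate for compound 3 in this assay is 25000 nM, within 10000 nM to 60000 nM. The expected step from compound 1 to compound 3 is a 1.1-fold higher number from compound 1 to compound 3 (0.04 log units; within the scatter).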

Compound 3, half-maximal inhibitory concentration: 3400 nM
Beside the measured number, compound 3's estimate is 7.4-fold (0.87 log units) above it, outside the stated range (below it).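

Going by these compounds alone, the swap of phenyl for phenoxy gives the first readable step in this assay, a 6.8-fold lower number from compound 1 to compound 3 (0.83 log units; beyond the scatter), which shows that the number responds to a change at this aromatic carbon, para to a large group. Phenyl and phenoxy each carry one six-membered aromatic ring of carbon only, so in this pair the presence of that ring does not alone fix the reading, and the two compounds part on what enters with the phenoxy group. The data give no measured property that accounts for the size of this step, and its cause stays unassigned.

The compounds shown leave open whether the oxygen atom itself matters or whether any link that sets the outer ring further out would do the same, a question that a methylene, a sulfur or an amine link at this carbon would address. They also leave open how far the step depends on the outer ring as it stands, for instance whether a chlorine on the phenoxy ring or a pyridine in its place would move the number further or return it towards that of compound 1.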